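The compounds below may be only part of what the source reports. "The series", "measured", "known", "first", "only" and "open" are said of these compounds alone.

Compound 1 `CC1=CCC[C@](C)(CC/C(C)=C/CC2=C(O)C(=O)C=C(N[C@@H](CO)C(=O)O)C2=O)[C@@H]1C`, in an ADME assay on L1210 cells (Mus musculus) for cytotoxicity, with a stated time of 48 h; on this read-out lower numbers stand for stronger inhibition and higher numbers for weaker inhibition: > 10 ug/mL, a limit
Compound 2 `CC1=CCC[C@](C)(CC/C(C)=C/CC2=C(O)C(=O)C=C(N[C@H](CO)C(=O)O)C2=O)[C@@H]1C`, in this assay: > 10 ug/mL, a limit

Compound 2 has no numerical value on this read-out, only its limit of > 10 ug/mL. Compound 1 shares this position, as shown by the limit of > 10 ug/mL in this assay, at which 2 of the 2 values shown sit. Within the data shown here, the one measured step is a step that the two limits leave unreadable from compound 1 to compound 2. It bears only indirectly on what follows, given (the fact that compounds 1 and 2 differ only in the configuration as drawn).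

Compound 3 `COC1=CC(=O)C(O)=C(C/C=C(\C)CC[C@@]2(C)CCC=C(C)[C@H]2C)C1=O` has not yet been measured in this assay. Its structural change is methoxy in place of (1-carboxy-2-hydroxyethyl)amino on a double-bonded ring carbon of a six-membered non-aromatic ring of carbon only. Among the measured compounds shown here, no measured step tests a change at this place, and both measured compounds carry the group that leaves. Any forecast is therefore weakly anchored, and a result at the limit again would not be surprising. A move toward stronger inhibition is nevertheless expected, and the estimated change is an at least 2.5-fold lower number from compound 2 to compound 3 (0.39 log units; beyond the scatter). The estimate for compound 3 is 4 ug/mL, with the measurement expected to fall between 1 ug/mL and 15 ug/mL.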

Compound 3, half-maximal inhibitory concentration: 2 ug/mL
For compound 3 the middle estimate is 2.0-fold (0.30 log units) above the measured one, and the stated range covers the measured number.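

Among these compounds, with methoxy in place of (1-carboxy-2-hydroxyethyl)amino on the double-bonded ring carbon, this assay gives a readable change at this position for the first time, with an at least 5.0-fold lower number from compound 2 to compound 3 (0.69 log units; beyond the scatter) and an at least 5.0-fold lower number from compound 1 to compound 3 (0.69 log units; beyond the scatter). Compound 3 is the only compound shown that carries a number and not a limit, so both steps give only a lower bound on the size of the change: the limit of > 10 ug/mL in this assay, at which 2 of the 3 values shown sit. The two steps start from opposite drawn configurations of the departing group and share the same lower bound, so the effect of the replacement does not depend on which of the two starting compounds is taken: the fact that compounds 1 and 2 differ only in the configuration as drawn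

The change removes the amino nitrogen, the carboxylic acid and the hydroxy group of the chain in a single move, and the compounds shown leave open which of these parts matters. They also leave open how a plain amine or a longer alkoxy chain at this place would read, and how far the true steps reach beyond their lower bounds.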